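Swapping Quinoline for a Chloropyridine at One Ring Carbon

The source may report more compounds than this note shows. Statements on the series, on what has been measured and on what is new or still open speak of the compounds shown alone.

Among the compounds with values here, in a functional assay on MDA-MB-231 cells (Homo sapiens) for antiproliferative activity, read by MTT assay, with a stated time of 48 h (a higher number here means a weaker inhibitor, a lower number a stronger inhibitor), compound 1 (`C=CS(=O)(=O)N1CCN(c2ncnc3sc(-c4ccc(C(F)(F)F)cc4)cc23)CC1`) gives 6410 nM and marks the stronger end of the series so far. Compound 2 (`C=CS(=O)(=O)N1CCN(c2ncnc3sc(-c4cccc5ccccc45)cc23)CC1`) gives 23700 nM and compound 3 (`C=CS(=O)(=O)N1CCN(c2ncnc3sc(-c4cccc5ncccc45)cc23)CC1`) gives 21000 nM at the weaker end. These two cannot be told apart, with a 1.1-fold lower number from compound 2 to compound 3 (0.05 log units; within the scatter) separating them.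

Compound 4 (`C=CS(=O)(=O)N1CCN(c2ncnc3sc(-c4ccnc(Cl)c4)cc23)CC1`) has 2-chloropyridin-4-yl in place of quinolin-5-yl on an aromatic carbon next to the ring sulfur (2-chloropyridin-4-yl in place of quinolin-5-yl on an aromatic carbon). Within the data shown here, no measured compound carries this group, so the nearest guide is compound 1, which also has one six-membered aromatic ring at this place. Its comparisons are a 3.7-fold higher number from compound 1 to compound 2 (0.57 log units; beyond the scatter) and a 3.3-fold higher number from compound 1 to compound 3 (0.52 log units; beyond the scatter) and both are modest. Dropping the second ring may therefore recover part of that gap, though the new group differs from the one in compound 1. In this assay the expected change is a 1.8-fold lower number from compound 3 to compound 4 (0.24 log units; within the scatter) by estimate, a small move toward a lower number. For compound 4 the estimated value is 12000 nM with an expected range of 4500 nM to 30000 nM before any measurement.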

Compound 4, half-maximal inhibitory concentration: 27700 nM
Compound 4: the middle estimate sits 2.3-fold (0.36 log units) below what was measured, within the range that was stated.
By their numbers in this assay, from the lowest: compound 1; then compounds 3, 2 and 4 (each within the scatter of the next).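

In this assay, a single ring at this position does not set compound 4 apart from the two-ring groups, with the quinolin-5-yl swap giving a 1.3-fold higher number from compound 3 to compound 4 (0.12 log units; within the scatter) and the naphthalen-1-yl swap giving a 1.2-fold higher number from compound 2 to compound 4 (0.07 log units; within the scatter). Having only one six-membered aromatic ring is therefore not enough to match compound 1, as the comparison with 4-(trifluoromethyl)phenyl gives a 4.3-fold higher number from compound 1 to compound 4 (0.64 log units; beyond the scatter), so which single ring sits here and what it carries matters. No measurement at hand explains this difference.

On these data alone, it remains open how a pyridin-4-yl ring would behave with an amine or a methoxy group in place of the chlorine. Also open, as far as these compounds go, is whether a plain phenyl ring, without its trifluoromethyl group, would keep the advantage of compound 1.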